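Swapping a bromine for a nitro group on the core

The source may hold more compounds than are shown below. What is called first, only, known or untested is meant among the compounds shown, and "the series" means these compounds.

Of the compounds shown here, three built on one shared core have been tested in a functional assay on the whole organism with Rattus norvegicus as the target, at a dose of 20 mg/kg by the intraperitoneal route; on this read-out higher numbers stand for more inhibition at the one dose given (going by the name of the read-out) and lower numbers for less inhibition. Compound 1, `Nc1nc(N)nc(-c2ccccc2Br)n1`, gives 26% and stands second highest of the three numbers. Compound 3, `Nc1nc(N)nc(-c2cc(Br)ccc2Cl)n1`, gives 86%, a number well above compound 1 and beyond the scatter. Compound 2, `CS(=O)(=O)c1cccc(-c2nc(N)nc(N)n2)c1`, gives -6%, a number below compound 1 and also beyond the scatter. No pair among these three differs in only one place, so no single structural step can be read off from the measured set.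

The next compound, compound 4, `Nc1nc(N)nc(-c2ccccc2[N+](=O)[O-])n1`, differs from compound 1 in one place: nitro in place of bromo on an aromatic carbon. Nothing measured here tells how a nitro group behaves on this core, so the expectation rests on the spread already seen. Going by the values given here, compound 1 sits in the middle of that spread, and the one polar group present, in compound 2, goes with the lowest number. On this basis a small step in this assay is expected for compound 4, and the step from compound 1 is estimated as a number 6 percentage points lower from compound 1 to compound 4 (within the scatter), a change likely within the scatter. For compound 4 the estimated inhibition is 20%, within a range from -10% to 50%.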

Compound 4, a percentage reported as inhibition, in the whole organism at one dose (the size of the read-out at that dose, not a potency): 11%
The estimate for compound 4 lay 9 percentage points above the measured number, within the range that was stated.
By their numbers in this assay, from the lowest: compound 2; then compound 4; then compound 1; then compound 3.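

Going by these compounds alone, this is the first comparison on the shared core in which only one place changes, so a shift in the number can be tied to a single swap. In this assay, nitro in place of bromo on the aromatic carbon gives a number 15 percentage points lower from compound 1 to compound 4 (beyond the scatter), so the group at this place does matter, although this step is modest. The swap replaces a single bromine with a group of three heavy atoms and two hydrogen-bond acceptors, but no measurement here bears on which of these differences, if any, lies behind the lower number.

Within the data shown here, with only two groups compared at this carbon, it remains open how an amine, a methoxy group or a carboxylic acid would compare with bromo and nitro, and so whether any group here could raise the number rather than lower it. On these data alone, it is also open whether the same swap would produce a step of similar size on a compound carrying a second group on the same six-membered ring.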